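Aryl urea variation on a shared thienopyrimidine-type core

The source may hold more compounds than are shown below. What is called first, only, known or untested is meant among the compounds shown, and "the series" means these compounds.

Two compounds of the series have numbers in a functional assay on NCI-H460 cells (Homo sapiens) for cytotoxicity, read by MTT assay, with a stated time of 72 h; on this read-out lower numbers stand for stronger inhibition and higher numbers for weaker inhibition. Compound 1 `CN(C)CCNc1nc(-c2ccc(NC(=O)Nc3ccccc3F)cc2)nc2ccsc12` gives 410 nM in this assay. Compound 2 `CN(C)CCNc1nc(-c2ccc(NC(=O)Nc3ccc(Cl)cc3)cc2)nc2ccsc12` gives 130 nM in this assay. Among the measured compounds shown here, the single measured step is a 3.2-fold lower number from compound 1 to compound 2 (0.50 log units; beyond the scatter), a change of the aryl ring on the urea. For the measured compounds named here, on these two numbers compound 2 stands lowest, with compound 1 as its only neighbour.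

Compound 3 `CN(C)CCNc1nc(-c2ccc(NC(=O)Nc3ccc(Cl)cc3Cl)cc2)nc2ccsc12` is not yet measured. It differs from compound 2 by chloro in place of hydrogen on an aromatic carbon, the added chloro sitting ortho to a large group and meta to the chloro group already present. Going by the values given here, no measured step adds a second substituent to this ring; the step from compound 1 to compound 2 exchanges one substituted ring for another and bears only loosely on this change. The expected step is therefore a 1.2-fold higher number from compound 2 to compound 3 (0.09 log units; within the scatter), within the scatter. Compound 3 is estimated at 160 nM in this assay, with a range from 60 nM to 450 nM.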

Compound 3, half-maximal inhibitory concentration: 1650 nM
For compound 3 the middle estimate is 10-fold (1.01 log units) below the measured one; measured number outside the range, above it.
By their numbers in this assay, from the lowest: compound 2; then compound 1; then compound 3.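

In this assay, the position ortho to a large group on the 4-chlorophenyl ring proves far from neutral: adding chloro there gives a 13-fold higher number from compound 2 to compound 3 (1.10 log units; beyond the scatter), a large step and a clear loss on this read-out. The 2,4-dichlorophenyl ring also falls behind the 2-fluorophenyl ring, with a 4.0-fold higher number from compound 1 to compound 3 (0.60 log units; beyond the scatter), so the advantage of compound 2 over compound 1 is not kept once this chloro enters. Within these compounds, the second substituent on the ring therefore matters more than the exchange of one singly substituted ring for another.

Open, from the compounds shown here alone, is how methoxy or an amine at this position would read, and whether the rise depends on the chloro group already present on the ring. No measurement at hand speaks to the origin of this rise.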